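Small acyl change on compound 1: methyl to cyclopropyl

This account rests on a few compounds, and the source may have more. Where it says the series, first, only, none or still open, it means among the compounds named here.

compound 1 `CC(=O)Nc1ccn([C@@H]2CO[C@H](CO)O2)c(=O)n1`: 6870 nM
compound 2 `CCCCCCCCCCCCCCCCCC(=O)Nc1ccn([C@@H]2CO[C@H](CO)O2)c(=O)n1`: 25 nM
compound 3 `O=C(Nc1ccn([C@@H]2CO[C@H](CO)O2)c(=O)n1)C1CC1`: not yet measured

Among the compounds with values here, in a functional assay on A549 cells (Homo sapiens) for cytotoxicity, read by sulforhodamine B assay, with a stated time of 72 h (on this read-out lower numbers stand for stronger inhibition and higher numbers for weaker inhibition), compound 1 gives 6870 nM, the higher of the two numbers so far, well above compound 2 at 25 nM in the same read-out. Compound 3 has cyclopropyl in place of methyl on a carbonyl carbon. Within the data shown here, no measured pair isolates this change. Among the measured compounds shown here, compound 2 also differs from compound 1 on that carbonyl carbon, and the value of compound 2 at 25 nM is the only guide to direction, though its group is far larger than cyclopropyl. A small move toward lower numbers is therefore expected, probably not beyond the scatter, and the estimated step is a 1.5-fold lower number from compound 1 to compound 3 (0.18 log units; within the scatter) in this assay on this basis. Compound 3 is estimated at 4500 nM (expected range 1500 nM to 12000 nM).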

Compound 3, half-maximal inhibitory concentration: 18700 nM
For compound 3 the middle estimate is 4.2-fold (0.62 log units) below the measured one; the whole stated range lies below it.
By their numbers in this assay, from the lowest: compound 2; then compound 1; then compound 3.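

In this assay, within the data shown here, cyclopropyl in place of methyl on a carbonyl carbon gives the first isolated step at this position (a 2.7-fold higher number from compound 1 to compound 3 (0.43 log units; beyond the scatter)), and it runs toward weaker inhibition. The position therefore responds to a change of only a few carbons, and added carbon alone does not go with lower numbers: compound 3 has more carbon than compound 1 yet stands higher, whereas compound 2, with its far longer chain, gives 25 nM in the same read-out. Nothing measured here accounts for the step.

Open, on these data alone, is whether the higher number belongs to the three-membered ring itself or would also appear with an open branched group such as isopropyl. Also open, as far as these compounds go, is how the numbers move along straight chains of intermediate length, such as butyl or octyl, between the methyl of compound 1 and the long chain of compound 2.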